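Two Ring Stereocentres Inverted in a Pyrrolidine Series

The source may hold more compounds than are shown below. What is called first, only, known or untested is meant among the compounds shown, and "the series" means these compounds.

Compound 3 `CCCCCCCCc1ccc(CC(O)[C@@H]2C[C@@H](O)CN2)cc1` is measured in a functional assay on FL5.12 cells (Mus musculus), read by flow cytometry, with a stated time of 3 h, tested at 2.5 uM (on this read-out higher numbers stand for a stronger effect at the one concentration tested and lower numbers for a weaker effect), where compound 3 gives 19%. On the numbers available it stands second highest of three. Its nearest neighbour is compound 2 `CCCCCCCCc1ccc(C(C[C@@H]2CCCN2)OC)cc1`, which in this assay gives 16%, a gap that lies within the scatter. Furthest from it is compound 1 `CCCCCCCCc1ccc(CC[C@@H]2CCCN2)cc1`, which in this assay gives 41%, a gap beyond the scatter.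

Compound 4 `CCCCCCCCc1ccc(CC(O)[C@H]2C[C@H](O)CN2)cc1` is not yet measured. It differs from compound 3 as follows: the two compounds have the same atoms and bonds; at least one stereo element is drawn with a configuration in one of them and without one in the other: 2 of 3 stereo elements differ; a stereocentre at a saturated ring carbon is drawn S in compound 3 and R in compound 4; a stereocentre at a saturated ring carbon is drawn R in compound 3 and S in compound 4.

Within the data shown here, the only step measured between two compounds that differ in one place is a number 25 percentage points lower from compound 1 to compound 2 (beyond the scatter). That step concerns a methoxy in place of hydrogen, not an inversion of stereocentres, so it does not bear on the change from compound 3 to compound 4. Among the measured compounds shown here, no measured pair here shows what inverting two ring stereocentres does in this assay. For the measured compounds named here, with no guiding step, compound 4 is expected to sit close to compound 3, with the step of a number 4 percentage points lower from compound 3 to compound 4 (within the scatter) estimated to lie within the scatter, though a wider range is allowed. For compound 4 the estimate in this assay is 15%, with a range from 4% to 35%.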

Compound 4, a percentage reported as activity, at one concentration (the size of the read-out at that concentration, not a potency): 9%
Beside the measured number, compound 4's estimate is 6 percentage points above it; low and high end bracket the measured number.
By their numbers in this assay, from the lowest: compounds 4, 2 and 3 (each within the scatter of the next); then compound 1.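

Inverting the two ring stereocentres gives the first measured read on this kind of change in the series: a number 10 percentage points lower from compound 3 to compound 4 (within the scatter) in this assay. Among these compounds, at the one concentration tested, this assay therefore does not separate the two drawn configurations of the shared core, whereas the only earlier step, the methoxy change, did lie beyond the scatter and said nothing about stereochemistry. Even this reading carries a reservation, as the two drawings are not fully matched and the comparison rests on: the fact that one of compounds 3 and 4 is drawn with a defined configuration and the other without, at the place where they differ.

The compounds shown leave open what either ring stereocentre does when inverted alone, since both change together here, and whether a difference would emerge at another concentration. They also leave open how a carboxylic acid or an amine on the shared core, or a longer chain in place of the present one, would behave alongside these configurations in this assay.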